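Benzimidazolone to cyanoindole on the piperazine side chain

A few compounds are considered here, and "the series" means these few. Any claim that something is new, unique, unknown or untested is made for them only; others in the source may bear on it.

In an assay on RPMI-8226 cells for antagonist activity at P2X purinoceptor 7 (Homo sapiens), read by calcium flux (on this read-out higher numbers stand for weaker inhibition and lower numbers for stronger inhibition), compound 3 `O=c1[nH]c2ccccc2n1CCCCCN1CCN(C(c2ccccc2)c2ccccc2)CC1` gives 560 nM, the lowest of the two numbers recorded. Compound 1 `O=C(C(c1ccccc1)c1ccccc1)N1CCN(CCCn2c(=O)[nH]c3ccccc32)CC1` gives 7800 nM in this assay, a gap from compound 3 that lies beyond the usual scatter. Compound 2 `Cc1ccc(S(=O)(=O)N2CCN(CCCn3c(=O)[nH]c4ccccc43)CC2)cc1` reaches only the limit of this assay, > 10000 nM, and so yields no number. Within the data shown here, no single-point step between measured compounds is available, so the measured values give a spread rather than a trend.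

Compound 4 `N#Cc1ccc2c(ccn2CCCCN2CCN(C(c3ccccc3)c3ccccc3)CC2)c1` differs from compound 3 in one place: a group of 11 heavy atoms (9 carbon, 2 nitrogen; one five-membered aromatic ring with 1 hetero atom, one six-membered aromatic ring of carbon only) in place of a group of 11 heavy atoms (8 carbon, 2 nitrogen, 1 oxygen; one five-membered aromatic ring with 2 hetero atoms, one six-membered aromatic ring of carbon only), on a saturated chain carbon, four bonds along the chain from an amine nitrogen in a ring. The group that leaves is the one that carries the hydrogen-bond donor of compound 3, and the group that enters, the 5-cyano-1H-indol-1-yl, carries none, sitting on a saturated chain carbon, four bonds along the chain from an amine nitrogen in a ring. Among the measured compounds shown here, nothing among the measured compounds shows how this assay responds to such an exchange, so the expectation rests on the value of compound 3 alone. The step from compound 3 to compound 4 is expected to be small, a 1.6-fold higher number from compound 3 to compound 4 (0.21 log units; within the scatter), within or near the scatter. For compound 4 the expected value in this assay is 900 nM, with a range from 200 nM to 4000 nM.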

Compound 4, half-maximal inhibitory concentration: 3800 nM
Beside the measured number, compound 4's estimate is 4.2-fold (0.63 log units) below it, and the stated range covers the measured number.
By their numbers in this assay, from the lowest: compound 3; then compound 4; then compound 1. At a limit, above all of these: compound 2.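

The exchange at this place, on a saturated chain carbon, four bonds along the chain from an amine nitrogen in a ring, moves the number in this assay: putting the 5-cyano-1H-indol-1-yl where the group of compound 3 stood gives a 6.8-fold higher number from compound 3 to compound 4 (0.83 log units; beyond the scatter) and a weaker inhibitor. Among these compounds, compounds 1, 2 and 3 offered no step that differs in one place, so this is the first direct reading of how this place responds, and it shows that the group here cannot be exchanged freely even when the two groups match in heavy-atom count. The group that leaves carries a hydrogen-bond donor and the group that enters carries none, but nothing shown ties the step to that difference or to any other.

From the compounds shown here alone, what remains open is whether a longer chain carrying the 5-cyano-1H-indol-1-yl would recover the number of compound 3. Going by these compounds, it is equally open how a carboxylic acid or an amine in place of the nitrile on that group would read in this assay.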